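The source may hold more compounds than are shown below. What is called first, only, known or untested is meant among the compounds shown, and "the series" means these compounds.

Measured so far in a functional assay on Jurkat cells for inhibition of nuclear factor NF-kappa-B complex (Homo sapiens); a higher number here means a weaker inhibitor, a lower number a stronger inhibitor:
- compound 1, `CCOC(=O)c1cnc(SC)nc1NN1C(=O)C=C(C)C1=O`, gives 200 nM
- compound 2, `CCOC(=O)c1cnc(-c2ccncc2)nc1NN1C(=O)C=C(C)C1=O`, gives 6000 nM
- compound 3, `CCOC(=O)c1cnc(-c2cccc([N+](=O)[O-])c2)nc1NN1C(=O)C=C(C)C1=O`, gives 7000 nM

Compound 1 stands lowest of the three. Its nearest neighbour is compound 2, with a 30-fold higher number from compound 1 to compound 2 (1.48 log units; beyond the scatter), and compound 3 lies a little further off, with a 35-fold higher number from compound 1 to compound 3 (1.54 log units; beyond the scatter). Compound 4, `CCOC(=O)c1cnc(C(=O)c2ccco2)nc1NN1C(=O)C=C(C)C1=O`, has not yet been measured in this assay. It differs from compound 1 in one place: (furan-2-yl)carbonyl in place of methylsulfanyl on an aromatic carbon. Both measured steps away from compound 1 swapped the same methylsulfanyl group for a group carrying an aromatic ring, and both were large rises. Compound 4 likewise brings an aromatic ring into that place, so a large rise in this assay is expected. For compound 4 the estimated value is 4000 nM, in the range 1000 nM to 20000 nM, corresponding to an expected 20-fold higher number from compound 1 to compound 4 (1.30 log units; beyond the scatter).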

Compound 4, half-maximal inhibitory concentration: 700 nM
The estimate for compound 4 lay 5.7-fold (0.76 log units) above the measured number, outside the stated range (below it).
By their numbers in this assay, from the lowest: compound 1; then compound 4; then compounds 2 and 3 (each within the scatter of the next).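

A ring at this place need not cost as much as compounds 2 and 3 suggested: with the ring held on a carbonyl, the rise shrinks to a 3.5-fold higher number from compound 1 to compound 4 (0.54 log units; beyond the scatter) and is still beyond the scatter, so methylsulfanyl keeps the lowest number. Against the two groups attached through a ring carbon, the (furan-2-yl)carbonyl group gains clearly, with a 10-fold lower number from compound 3 to compound 4 (1.00 log units; beyond the scatter) and an 8.6-fold lower number from compound 2 to compound 4 (0.93 log units; beyond the scatter) in the comparison. No measurement at hand explains these differences. The compounds shown cannot separate the part played by the carbonyl from that of the furan ring. Going by these compounds, a benzoyl group, a plain furan-2-yl group or an amine at this place remains untested here.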